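Thiophene sulfonamide thioureas: ether replacement on the aryl ring

This account rests on a few compounds, and the source may have more. Where it says the series, first, only, none or still open, it means among the compounds named here.

Measured so far:
compound 1 `O=[N+]([O-])c1ccc(NC(=S)NCCNS(=O)(=O)c2ccc(-c3ccccc3O[C@H]3CC[C@@H](O)CC3)s2)cc1`, > 20000 nM
compound 2 `O=S(=O)(NCCNC(=S)Nc1cc(C(F)(F)F)cc(C(F)(F)F)c1)c1ccc(-c2ccccc2OCc2ccccc2)s1`, 4700 nM

Compound 1 gives only a limit of the assay in a functional assay on HeLa cells (Homo sapiens) for inhibition, read by CCK-8 assay, with a stated time of 48 h (a lower number here means a stronger inhibitor, a higher number a weaker inhibitor), namely > 20000 nM; one of the two values shown sits there (the limit of > 20000 nM in this assay, at which 1 of the 2 values shown sits). Within the data shown here, compound 2 is the only compound with a numeric value, 4700 nM.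

Compound 3 `O=S(=O)(NCCNC(=S)Nc1cc(C(F)(F)F)cc(C(F)(F)F)c1)c1ccc(-c2ccccc2O[C@H]2CC[C@@H](O)CC2)s1` differs from compound 2 by 4-hydroxycyclohexyl in place of benzyl on an oxygen on an aromatic ring. Compound 1 carries the same 4-hydroxycyclohexyl group and reaches only the limit > 20000 nM. Compound 3 is therefore expected to be a weaker inhibitor than compound 2, with a step of a 2.6-fold higher number from compound 2 to compound 3 (0.41 log units; beyond the scatter) beyond the usual scatter. The estimate for compound 3 is 12000 nM, within 4000 nM to 40000 nM.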

Compound 3, half-maximal inhibitory concentration: 10900 nM
For compound 3 the middle estimate is 1.1-fold (0.04 log units) above the measured one; the range from low to high includes it.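

In this assay, the change to 4-hydroxycyclohexyl on the oxygen gives a 2.3-fold higher number from compound 2 to compound 3 (0.37 log units; beyond the scatter) and still leaves a numeric value, so this position accepts a non-aromatic ring carrying a hydroxy group at a modest cost. This ether alone does not take compound 3 to the limit of the assay. Compound 1, with the same ether, gives > 20000 nM as a limit of the assay.

Going by these compounds, whether an amine or a carboxylic acid in place of that hydroxy group would restore or further weaken inhibition stays open. Nothing shown accounts for the step.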